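A few compounds are considered here, and "the series" means these few. Any claim that something is new, unique, unknown or untested is made for them only; others in the source may bear on it.

Of the compounds shown here, two with the same core have been measured in a functional assay on SW-620 cells (Homo sapiens) for cytotoxicity, read by sulforhodamine B assay, with a stated time of 48 h; on this read-out lower numbers stand for stronger inhibition and higher numbers for weaker inhibition. Compound 1 `C[C@H]1CC[C@@H]2[C@@H](OC(=O)[C@]23CC(c2ccccc2Br)=NO3)[C@]2(C)C(=O)C=C[C@@]12O`, with a 2-bromophenyl group, gives 44000 nM. Compound 2 `C[C@H]1CC[C@@H]2[C@@H](OC(=O)[C@]23CC(c2ccc(N(C)C)cc2)=NO3)[C@]2(C)C(=O)C=C[C@@]12O`, with a 4-(dimethylamino)phenyl group, gives 5100 nM, the lower of the two numbers. Compound 3 `C[C@H]1CC[C@@H]2[C@@H](OC(=O)[C@]23CC(c2ccc([N+](=O)[O-])cc2)=NO3)[C@]2(C)C(=O)C=C[C@@]12O` keeps everything except one group: it has nitro in place of dimethylamino on an aromatic carbon. Among the compounds with values here, only one measured step bears on this change: an 8.6-fold lower number from compound 1 to compound 2 (0.94 log units; beyond the scatter), a modest step beyond the scatter. Within the data shown here, it shows that swapping this aromatic group can move the number, but no measured compound carries a nitro group. Among the measured compounds shown here, with compound 2 at 5100 nM as the lowest number so far, a rise of similar or smaller size is expected. The estimated step is a 2.7-fold higher number from compound 2 to compound 3 (0.44 log units; beyond the scatter). For compound 3 the expected value is 14000 nM, with an estimated range of 4500 nM to 45000 nM.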

Compound 3, half-maximal inhibitory concentration: 9000 nM
The estimate for compound 3 lay 1.6-fold (0.19 log units) above the measured number, and the stated range covers the measured number.
By their numbers in this assay, from the lowest: compounds 2 and 3 (each within the scatter of the next); then compound 1.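

In this assay, nitro in place of dimethylamino on an aromatic carbon gives a 1.8-fold higher number from compound 2 to compound 3 (0.25 log units; within the scatter), so this swap, with its change of atoms, leaves the number within the usual scatter. The 4-nitrophenyl group also differs clearly from 2-bromophenyl, with a 4.9-fold lower number from compound 1 to compound 3 (0.69 log units; beyond the scatter), which shows that the lower number seen with compound 2 is not tied to dimethylamino alone: compound 2 and compound 3 both stand apart from compound 1. No measurement at hand explains why these two groups give such similar numbers.

From the compounds shown here alone, whether the number for compound 1 follows from the bromine itself or from where it sits remains open, and a 4-bromophenyl group would test this. Going by these compounds, what a carboxylic acid, a primary amine or an unsubstituted phenyl would give in this place also remains unknown.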